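The source may report more compounds than this note shows. Statements on the series, on what has been measured and on what is new or still open speak of the compounds shown alone.

Measured compounds in an ADME assay on HepG2 2.2.15 cells (Homo sapiens) for cytotoxicity; on this read-out lower numbers stand for higher toxicity in this test and higher numbers for lower toxicity in this test:
- compound 1 `CC(=O)NCC(=O)OCCc1c(-c2ccccc2Cl)c2cc(Cl)ccc2[nH]c1=O` gives 110000 nM.
- compound 2 `O=C(OCCc1c(-c2ccccc2Cl)c2cc(Cl)ccc2[nH]c1=O)c1ccco1` gives 98000 nM.
- compound 3 `COc1ccc(/C=C/C(=O)OCCc2c(-c3ccccc3Cl)c3cc(Cl)ccc3[nH]c2=O)cc1` gives > 1200000 nM, which is a limit of the test and not a number.

Of the two numbers shown, compound 1 stands highest, with compound 2 nearest: a 1.1-fold lower number from compound 1 to compound 2 (0.05 log units; within the scatter). The third value shown is the limit belonging to compound 3.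

The step to compound 4 `COc1ccc(/C=C/C(=O)OCCc2c(-c3ccccc3Cl)c3cc(Cl)ccc3[nH]c2=O)cc1OC` alters compound 1 at the ester carbonyl: 2-(3,4-dimethoxyphenyl)ethenyl in place of acetamidomethyl on a carbonyl carbon. For the measured compounds named here, two measured steps bear on it, both putting a 2-(4-methoxyphenyl)ethenyl on the same carbonyl carbon: an at least 10-fold higher number from compound 1 to compound 3 (1.03 log units; beyond the scatter) and an at least 12-fold higher number from compound 2 to compound 3 (1.08 log units; beyond the scatter). Both run up to the limit of > 1200000 nM in this assay, at which 1 of the 3 values shown sits, so their true size is not known, only that it is large and toward higher numbers. The 2-(3,4-dimethoxyphenyl)ethenyl entering compound 4 differs from that group by an additional methoxy, so the same kind of behaviour is anticipated.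

Given an at least 10-fold higher number from compound 1 to compound 3 (1.03 log units; beyond the scatter) and an at least 12-fold higher number from compound 2 to compound 3 (1.08 log units; beyond the scatter), compound 4 is expected to move far toward higher numbers in this assay, most likely again reaching the limit. Compound 4 is thus estimated at 1200000 nM, with a range from 400000 nM to 3000000 nM. The expected step is an 11-fold higher number from compound 1 to compound 4 (1.04 log units; beyond the scatter).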

Compound 4, half-maximal cytotoxic concentration: > 1200000 nM
Compound 4: only a limit was reported; the forecaster's own chance of this, stated with the estimate: 65%; the middle value lies on the limit itself.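

In this assay, a second aromatic ethenyl group on the ester carbonyl gives the same large move as the first, with an at least 10-fold higher number from compound 1 to compound 4 (1.03 log units; beyond the scatter) and an at least 12-fold higher number from compound 2 to compound 4 (1.08 log units; beyond the scatter), so the effect at this position no longer rests on the 2-(4-methoxyphenyl)ethenyl group of compound 3 alone. Both steps end at a limit of the test, so they give only a minimum size, and the step between compound 3 and compound 4 cannot be read, which leaves the effect of the extra methoxy unknown: the limit of > 1200000 nM in this assay, at which 2 of the 4 values shown sit. Among the compounds shown, the two ethenyl-linked aryl groups sit at the limit, whereas the furan-2-yl of compound 2, also aromatic but with no ethenyl link, gives a number within the scatter of compound 1.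

Going by these compounds, whether the ethenyl link is needed remains open, and a saturated 2-(4-methoxyphenyl)ethyl group on the same carbonyl carbon would address this directly. Also open, on these data alone, is whether an amine or a carboxylic acid on the aromatic ring would keep the read-out at the limit or bring it back into the measurable range.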